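Swapping the amine substituent on the shared core

The source may hold more compounds than are shown below. What is called first, only, known or untested is meant among the compounds shown, and "the series" means these compounds.

Compound 1 `CC(C(=O)NCc1ccc(C(F)(F)F)nc1NC1CCCCC1)c1ccc(NS(C)(=O)=O)c(F)c1` gives 260 nM in a functional assay on CHO-K1 cells for antagonist activity at transient receptor potential cation channel subfamily V member 1 (Homo sapiens), read by FLIPR; a higher number here means a weaker inhibitor, a lower number a stronger inhibitor. Compound 2 `CC1CCC(Nc2nc(C(F)(F)F)ccc2CNC(=O)C(C)c2ccc(NS(C)(=O)=O)c(F)c2)CC1` gives 1130 nM. Compound 3 `CC(C(=O)NCc1ccc(C(F)(F)F)nc1NCc1ccccc1)c1ccc(NS(C)(=O)=O)c(F)c1` gives 203 nM.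

Compound 3 has the lowest number of the three, though its gap to compound 1 is within the scatter. Compound 4 `CCCN(CCC)c1nc(C(F)(F)F)ccc1CNC(=O)C(C)c1ccc(NS(C)(=O)=O)c(F)c1` differs from compound 3 by dipropylamino in place of benzylamino on an aromatic carbon. The steps at this position vary in weight: a 1.3-fold lower number from compound 1 to compound 3 (0.11 log units; within the scatter), whereas a 4.3-fold higher number from compound 1 to compound 2 (0.64 log units; beyond the scatter) and a 5.6-fold lower number from compound 2 to compound 3 (0.75 log units; beyond the scatter). So this position tolerates some change but not all, and the loss of the hydrogen-bond donor is untested. A modest rise in the number is expected, so a 3.0-fold higher number from compound 3 to compound 4 (0.47 log units; beyond the scatter) is the estimated step. Compound 4 is expected at 600 nM, within 150 nM to 2500 nM.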

Compound 4, half-maximal inhibitory concentration: 14.7 nM
The estimate for compound 4 lay 41-fold (1.61 log units) above the measured number, and the stated range ends above it.
By their numbers in this assay, from the lowest: compound 4; then compounds 3 and 1 (each within the scatter of the next); then compound 2.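

In this assay, dipropylamino, with no ring and no hydrogen-bond donor, beats all three ring-bearing amines at this position, with a 14-fold lower number from compound 3 to compound 4 (1.14 log units; beyond the scatter) and an 18-fold lower number from compound 1 to compound 4 (1.25 log units; beyond the scatter) and a 77-fold lower number from compound 2 to compound 4 (1.89 log units; beyond the scatter). The hydrogen-bond donor on this nitrogen is therefore not needed for activity here, and this position can shift the number much further than the earlier swaps suggested. No measurement at hand accounts for the gain.

As far as these compounds go, the ring and the donor leave together, so their separate contributions remain unknown. Propylamino, which keeps the donor without a ring, and piperidine, which has a ring without the donor, would pull them apart.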